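Methoxy on the core of compound 3: an expected value

This account rests on a few compounds, and the source may have more. Where it says the series, first, only, none or still open, it means among the compounds named here.

Three compounds have numbers in an assay on isolated protein for inhibition of Amine oxidase [flavin-containing] A (Homo sapiens), read by fluorescence and Amplex Red, with stated times of 15 min and 20 min, tested at 100 uM; a lower number here means less inhibition, a higher number more inhibition at the concentration tested (going by the name of the read-out). Compound 1 `COc1ccc2occ(C(=O)NC3CCN(Cc4ccccc4)CC3)c(=O)c2c1` gives 7.5% there. Compound 2 `O=C(NC1CCN(Cc2ccccc2)CC1)c1cc(=O)c2ccccc2o1` gives 29.7% in this assay. Compound 3 `O=C(NCCC1CCN(Cc2ccccc2)CC1)c1coc2ccccc2c1=O` gives 68.6% in this assay, the highest of the three numbers; its nearest neighbour is compound 2, whose number lies well beyond the scatter below it, and compound 1 lies further still below, also beyond the scatter.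

Compound 4 `COc1ccc2occ(C(=O)NCCC3CCN(Cc4ccccc4)CC3)c(=O)c2c1` has not yet been measured in this assay. It differs from compound 3 in one place: methoxy in place of hydrogen on an aromatic carbon. For the measured compounds named here, no pair of measured compounds differs in exactly this way, so no measured step shows what the change does. Compound 1 carries the methoxy as well, but it also differs from compound 3 elsewhere, so its low number cannot be read as the effect of the methoxy alone.

In this assay compound 4 is expected to give 55%, with a range from 25% to 80%. The step of a number 13.6 percentage points lower from compound 3 to compound 4 (beyond the scatter) is an estimate; a moderate drop is expected, wide enough in its range to allow no change beyond the scatter.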

Compound 4, a percentage reported as inhibition, at one concentration (the size of the read-out at that concentration, not a potency): 72.4%
Beside the measured number, compound 4's estimate is 17.4 percentage points below it; low and high end bracket the measured number.
By their numbers in this assay, from the lowest: compound 1; then compound 2; then compounds 3 and 4 (each within the scatter of the next).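

In this assay, for the compounds shown here, the first step that isolates this change is a number 3.8 percentage points higher from compound 3 to compound 4 (within the scatter), so compounds 3 and 4 cannot be told apart at the concentration tested, and methoxy in place of hydrogen on this aromatic carbon, meta to a fused ring and para to a fused ring, is compatible with the level of inhibition seen for compound 3. The low number of the other methoxy compound therefore does not follow from the methoxy alone: compound 1 gives 7.5% in this assay, whereas compound 4, with the methoxy at the same place, gives 72.4% there. Nothing available explains why the methoxy leaves the number within the scatter.

The compounds shown leave open whether a different group at this aromatic carbon, such as hydroxy, ethoxy or an amine, would also leave the number within the scatter, or whether only a small ether is compatible with it. They also leave open whether compounds 3 and 4 would still match in potency, since a reading at one concentration does not give one.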